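A few compounds are considered here, and "the series" means these few. Any claim that something is new, unique, unknown or untested is made for them only; others in the source may bear on it.

Measured compounds:
compound 1, `Cc1cc(C)c(N2CCCn3c2nc(C)c3C(=O)N(CC2CC2)CC2CC2)c(C)c1`: 3400 nM in an in vitro assay on IMR-32 cells for displacement of a labelled ligand from corticotropin-releasing factor receptor 1 (Homo sapiens); a higher number here means a weaker inhibitor, a lower number a stronger inhibitor
compound 2, `CCCN(CC1CCC1)C(=O)c1c(C)nc2n1CCCN2c1c(C)cc(C)cc1C`: 3300 nM in this assay

Compound 2 stands beside compound 1: the step of a 1.0-fold lower number from compound 1 to compound 2 (0.01 log units; within the scatter) lies within the scatter, so the two numbers cannot be told apart, and neither compound counts as the stronger.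

Compound 3, `CCCN(Cc1ccccc1)C(=O)c1c(C)nc2n1CCCN2c1c(C)cc(C)cc1C`, is not yet measured. It differs from compound 2 in one place: phenyl in place of cyclobutyl on a saturated chain carbon bound to an amide-type nitrogen.

Going by the values given here, the only measured step that bears on this change is the one from compound 1 to compound 2, which also reworked the groups on the amide-type nitrogen; it read a 1.0-fold lower number from compound 1 to compound 2 (0.01 log units; within the scatter), that is, no movement beyond the scatter. Exchanging one saturated ring for an aromatic one on the chain carbon at that nitrogen is a different kind of swap, and nothing measured here shows how far it can reach. The expectation is therefore a step of a 1.1-fold lower number from compound 2 to compound 3 (0.04 log units; within the scatter), no larger than the scatter, in no settled direction. Compound 3 is expected to give 3000 nM in this assay, with a range from 1000 nM to 9000 nM.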

Compound 3, inhibition constant: > 5000 nM
Compound 3: a limit, no number; the forecaster's own chance of this, stated with the estimate: 5%; at least 1.6-fold (0.22 log units) between middle value and limit.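

In this assay compound 3 gives > 5000 nM and this is a limit of the assay and not a number: the limit of > 5000 nM in this assay, at which 1 of the 3 values shown sits.

The earlier pair, compound 1 and compound 2, carries only saturated rings on the chain at the amide-type nitrogen, while compound 3 puts an aromatic ring of carbon at that place, with benzyl in place of cyclobutylmethyl. Going by these compounds, the step reads an at least 1.5-fold higher number from compound 2 to compound 3 (0.18 log units; that floor lies within the scatter) and so gives a floor and no size, which means that the true distance between the two compounds remains unknown and a real loss is not established. What the limit does show is that phenyl on this saturated chain carbon gives no reading stronger than that of compound 2, so the aromatic ring brings no visible gain at this place.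

On these data alone, what a cyclohexyl ring or a pyridine ring would read at this same place stays open, as does the effect of an amine or a hydroxyl group on the chain. As far as these compounds go, the trimethylphenyl group on the core is the same in all three compounds, so the reach of a methoxy group or a chlorine atom on that ring is also open.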